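The source may report more compounds than this note shows. Statements on the series, on what has been measured and on what is new or still open speak of the compounds shown alone.

In a functional assay on A549 cells (Homo sapiens) for cytotoxicity, read by MTT assay, with a stated time of 72 h (a higher number here means a weaker inhibitor, a lower number a stronger inhibitor), compound 1 `COc1ccc(/C=C2\CCC/C(=C\c3cccc(Cl)c3)C2=O)cc1OC` gives 11000 nM and compound 2 `COc1cccc(/C=C2\CCC/C(=C\c3ccc(OC)c(OC)c3)C2=O)c1` gives 6700 nM. Within the data shown here, compound 2 therefore lies within the scatter of compound 1, the only other compound measured so far. Compound 3 `COc1ccc(/C=C2\CCC/C(=C\c3cccc(Cl)c3Cl)C2=O)cc1OC` is reached from compound 2 by 2,3-dichlorophenyl in place of 3-methoxyphenyl on a double-bonded chain carbon bound to a double-bonded ring carbon. Among the measured compounds shown here, only one measured step bears on this change: a 1.6-fold lower number from compound 1 to compound 2 (0.22 log units; within the scatter), with methoxy in place of chloro on an aromatic carbon. For the measured compounds named here, no measured compound carries the 2,3-dichlorophenyl group, so the evidence is thin. With that single step as the guide, no shift beyond the scatter is expected in this assay. The expected change is a 1.2-fold higher number from compound 2 to compound 3 (0.08 log units; within the scatter). For compound 3 the estimated value is 8000 nM, with an expected range of 3000 nM to 20000 nM.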

Compound 3, half-maximal inhibitory concentration: > 20000 nM
Compound 3 ended at the assay's limit; the forecaster's own chance of this, stated with the estimate: 10%; middle value at least 2.5-fold (0.39 log units) away from the limit.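

Compound 3 stands at a limit of the assay, not at a number, in this assay: the limit of > 20000 nM in this assay, at which 1 of the 3 values shown sits. Even so, 2,3-dichlorophenyl in place of 3-methoxyphenyl on a double-bonded chain carbon bound to a double-bonded ring carbon gives an at least 2.9-fold higher number from compound 2 to compound 3 (0.47 log units; beyond the scatter), the only step among these compounds that goes beyond the scatter. Chloro in place of hydrogen on an aromatic carbon gives an at least 1.8-fold higher number from compound 1 to compound 3 (0.25 log units; that floor lies within the scatter), so this step alone does not show that the added chloro changes the reading.

Going by these compounds, how far past the limit compound 3 truly lies remains open, and the step from the chloro group to the 2,3-dichlorophenyl group therefore has no upper size. The compounds shown also leave open how an amine or a carboxylic acid on a phenyl ring in that place would read.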